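The source may hold more compounds than are shown below. What is called first, only, known or untested is meant among the compounds shown, and "the series" means these compounds.

Among the measured compounds shown here, compound 2 `NC(=O)c1ccccc1Nc1cccc(/C=C/C(=O)O)c1` stands lowest of the two numbers so far measured. In a functional assay on HCT-116 cells (Homo sapiens) for inhibition, read by resazurin assay, with a stated time of 24 h, tested at 100 uM (a higher number here means more inhibition at the concentration tested (going by the name of the read-out), a lower number less inhibition), compound 2 gives 0%, while its nearest neighbour compound 1 `NC(=O)c1ccccc1Nc1cccc(-c2ccccc2)c1` gives 126%. For the measured compounds named here, the only step measured between these compounds, a number 126 percentage points lower from compound 1 to compound 2 (beyond the scatter), is large and runs from the higher number to the lower one when 2-carboxyethenyl replaces phenyl on an aromatic carbon.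

Compound 3 `NC(=O)c1ccccc1Nc1cccc(CCO)c1` differs from compound 2 by 2-hydroxyethyl in place of 2-carboxyethenyl on an aromatic carbon. No measured step covers this exact change, so the expectation rests on the single step shown: the 2-carboxyethenyl group that leaves is the one whose arrival brought the number down, and the 2-hydroxyethyl group that enters has fewer heavy atoms and no double bond outside aromatic rings. A step upward in this assay is therefore expected from compound 2 to compound 3, but since neither the phenyl of compound 1 nor the 2-carboxyethenyl of compound 2 is present, its size is uncertain; the expected step is a number 35 percentage points higher from compound 2 to compound 3 (beyond the scatter). For compound 3 the estimated inhibition is 35%, with a range from 0% to 90%.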

Compound 3, a percentage reported as inhibition, at one concentration (the size of the read-out at that concentration, not a potency): 12%
The estimate for compound 3 lay 23 percentage points above the measured number, and the stated range covers the measured number.
By their numbers in this assay, from the lowest: compound 2; then compound 3; then compound 1.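

At this aromatic carbon, meta to a large group, exchanging 2-carboxyethenyl for 2-hydroxyethyl recovers only a little in this assay, where the modest change is a number 12 percentage points higher from compound 2 to compound 3 (beyond the scatter) and stands beyond the usual scatter. Measured against phenyl, the 2-hydroxyethyl group still falls far short, with a large drop of a number 114 percentage points lower from compound 1 to compound 3 (beyond the scatter) at the same place, so the low end of the scale is now held by two ringless chains and not by the 2-carboxyethenyl group alone. No experimental evidence is available to explain these differences.

The three compounds leave open whether the high number of compound 1 depends on an aromatic ring at this position or simply on the size of the group, since phenyl is the only ring-bearing group shown. A pyridyl ring, a benzyl group, a plain ethyl chain, an amine or a longer chain ending in hydroxyl on the same carbon would each test a different part of that question.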